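Cytotoxicity notes on amide variants of the shared core

A few compounds are considered here, and "the series" means these few. Any claim that something is new, unique, unknown or untested is made for them only; others in the source may bear on it.

Measured so far in a toxicity assay on THP-1 cells (Homo sapiens) for inhibition; on this read-out higher numbers stand for lower toxicity in this test and lower numbers for higher toxicity in this test:
compound 1 `COc1ccc(-c2cnc(NC(=O)c3ccc(F)cc3)n2Cc2ccccc2)cc1` gives > 100000 nM
compound 2 `Cc1ccc(-c2cnc(NC(=O)c3ccc(F)cc3)n2C)cc1` gives 60000 nM
compound 3 `COc1ccc(-c2cnc(NC(=O)c3cccc(O)c3)n2C)cc1` gives > 100000 nM

The value recorded for compound 1 is a limit of this assay, not a number. The value recorded for compound 3 is likewise a limit and not a number. Compound 2 is the only one of the three that returns a number. Compound 3 therefore stands at the ceiling of what this assay reports, which is where most of the series sits, as the limit of > 100000 nM in this assay, at which 2 of the 3 values shown sit, shows.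

Compound 4 `COc1ccc(-c2cnc(NC(=O)C3CCOCC3)n2C)cc1` is not yet measured. It differs from compound 3 in one place: oxan-4-yl in place of 3-hydroxyphenyl on a carbonyl carbon. Within the data shown here, no step between two measured compounds is available to calibrate this change, so the size of its effect in this assay rests on the series as a whole. With two of three compounds at the limit, the expectation for compound 4 is no step beyond the usual scatter, most likely again a limit.

For compound 4 the estimate in this assay is 100000 nM, with a range from 40000 nM to 300000 nM. This corresponds to an expected step of a number no higher from compound 3 to compound 4 (the limit leaves the size open) of essentially nothing, with a high chance that only a limit is reported.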

Compound 4, half-maximal cytotoxic concentration: > 100000 nM
Compound 4 gave a limit, no number (the forecaster's own chance of this, stated with the estimate: 70%); the middle value sits exactly at the limit.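

In this assay compound 4 gives > 100000 nM, which is a limit and not a number. Among these compounds, compound 3 also stands at a limit, so no step between compound 3 and compound 4 can be read. Most of the series sits at this ceiling: the limit of > 100000 nM in this assay, at which 3 of the 4 values shown sit. The compounds shown leave open whether oxan-4-yl and 3-hydroxyphenyl on a carbonyl carbon differ at all in this read-out.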